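Pyridinylmethyl amine returns at the thiocarbonyl carbon

The source may report more compounds than this note shows. Statements on the series, on what has been measured and on what is new or still open speak of the compounds shown alone.

Compound 2 `CC1CCN(C(=S)SCc2ccc(C(=O)Nc3ccccc3N)cc2)CC1` stands lowest of the two compounds measured in a functional assay on HeLa cells (Homo sapiens) for antiproliferative activity, read by CCK-8 assay, with a stated time of 72 h, tested at 2 uM (on this read-out lower numbers stand for a weaker effect and higher numbers for a stronger effect at the one concentration tested), where compound 2 gives 46.8%. Its nearest neighbour, compound 1 `CCN(Cc1ccncc1)C(=S)SCc1ccc(C(=O)Nc2ccccc2N)cc1`, gives 63.5% in this assay. Compound 3 `CN(Cc1ccncc1)C(=S)SCc1ccc(C(=O)Nc2ccccc2N)cc1` differs from compound 2 in one place: methyl((pyridin-4-yl)methyl)amino in place of 4-methylpiperidin-1-yl on a thiocarbonyl carbon. Among the measured compounds shown here, the only measured step that bears on this is a number 16.7 percentage points lower from compound 1 to compound 2 (beyond the scatter), which ran the opposite way, trading ethyl((pyridin-4-yl)methyl)amino for 4-methylpiperidin-1-yl. Reversing that change, now with methyl((pyridin-4-yl)methyl)amino rather than ethyl((pyridin-4-yl)methyl)amino, leads one to expect a rise of similar size, a number 13.2 percentage points higher from compound 2 to compound 3 (beyond the scatter). Compound 3 is therefore estimated at 60%, with a range from 46% to 72%.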

Compound 3, a percentage reported as inhibition, at one concentration (the size of the read-out at that concentration, not a potency): 29.5%
Estimate against measurement, compound 3: 30.5 percentage points above; measured number outside the range, below it.
By their numbers in this assay, from the lowest: compound 3; then compound 2; then compound 1.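

In this assay, the pyridinylmethyl amine does not by itself bring the effect back: methyl((pyridin-4-yl)methyl)amino on the thiocarbonyl carbon gives a number 17.3 percentage points lower from compound 2 to compound 3 (beyond the scatter), so the outcome of replacing 4-methylpiperidin-1-yl turns on the other chain at that amine nitrogen. That chain carries much of the effect, since hydrogen in place of methyl on it, taking ethyl down to methyl, gives a number 34 percentage points lower from compound 1 to compound 3 (beyond the scatter). No evidence at hand accounts for this drop. Still open, from the compounds shown here alone, is whether a propyl chain on that nitrogen would extend the rise seen with ethyl, and whether a pyridin-3-yl ring would behave like the pyridin-4-yl one.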